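Nitrogen substituent changes on a shared benzimidazole-acid series

This account rests on a few compounds, and the source may have more. Where it says the series, first, only, none or still open, it means among the compounds named here.

Measured in an assay on Huh-7 cells for agonist activity at Bile acid receptor (Homo sapiens), read by a luciferase reporter; a lower number here means that less compound is needed, a higher number that more compound is needed for the effect:
compound 1, `CC(=O)N1CCC(n2c(-c3ccc(OCc4c(-c5c(Cl)cccc5Cl)noc4C(C)C)cc3)nc3ccc(C(=O)O)cc32)CC1`: 1430 nM
compound 2, `CCCn1c(-c2ccc(OCc3c(-c4c(Cl)cccc4Cl)noc3C(C)C)cc2)nc2ccc(C(=O)O)cc21`: 9.3 nM
compound 3, `CC(C)c1onc(-c2c(Cl)cccc2Cl)c1COc1ccc(-c2nc3ccc(C(=O)O)cc3n2Cc2ccc(F)cc2)cc1`: 3.31 nM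

Compound 3 has the lowest number of the three; its nearest neighbour is compound 2, with the step of a 2.8-fold lower number from compound 2 to compound 3 (0.45 log units; beyond the scatter), and the furthest is compound 1, with a 430-fold lower number from compound 1 to compound 3 (2.64 log units; beyond the scatter). Compound 4, `CC(C)c1onc(-c2c(Cl)cccc2Cl)c1COc1ccc(-c2nc3ccc(C(=O)O)cc3n2CC2CCCCC2)cc1`, differs from compound 3 by cyclohexyl in place of 4-fluorophenyl on a saturated chain carbon bound to an aromatic nitrogen. Going by the values given here, the only step at this position among the measured compounds is a 2.8-fold lower number from compound 2 to compound 3 (0.45 log units; beyond the scatter), which is modest; no measured step shows cyclohexyl anywhere, so the direction rests on that single comparison. A modest change in this assay is expected, more likely toward a somewhat higher number than a lower one. For compound 4 the expected value in this assay is 6 nM, with a range of 2.5 nM to 15 nM. This estimate means the step of a 1.8-fold higher number from compound 3 to compound 4 (0.26 log units; within the scatter).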

Compound 4, half-maximal effective concentration: 0.52 nM
The estimate for compound 4 lay 12-fold (1.06 log units) above the measured number, outside the stated range (below it).
By their numbers in this assay, from the lowest: compound 4; then compound 3; then compound 2; then compound 1.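

At the saturated chain carbon bound to an aromatic nitrogen, an aromatic ring is not needed for low numbers in this assay: cyclohexyl outdoes 4-fluorophenyl (a 6.4-fold lower number from compound 3 to compound 4 (0.80 log units; beyond the scatter)). The step from ethyl is larger (an 18-fold lower number from compound 2 to compound 4 (1.25 log units; beyond the scatter)), and cyclohexylmethyl extends the distance from 1-acetylpiperidin-4-yl (a 2800-fold lower number from compound 1 to compound 4 (3.44 log units; beyond the scatter)). No available evidence bears on this preference for cyclohexyl. Still open, from the compounds shown here alone, is how unsubstituted benzyl compares with 4-fluorobenzyl and cyclohexylmethyl, and whether cyclopentylmethyl or cyclohexylethyl keeps the number of compound 4.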